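Methoxy for acetamido on a weak growth inhibitor

A few compounds are considered here, and "the series" means these few. Any claim that something is new, unique, unknown or untested is made for them only; others in the source may bear on it.

Measured so far in a functional assay on ACHN cells (Homo sapiens) for inhibition, read by sulforhodamine B assay; a lower number here means a stronger inhibitor of growth, a higher number a weaker inhibitor of growth:
Compound 1 (`COc1ccccc1CN1CCC=C(CCC(=O)NO)C1=O`): > 10000 nM
Compound 2 (`CC(=O)Nc1ccc(CN2CCC=C(CCC(=O)NO)C2=O)cc1`): "not determined" (no result reported)

Compound 2 gives no starting number, since in this assay compound 2 is recorded as "not determined" (no result reported) and nothing more. Going by the values given here, the only other reading is a limit, not a number: compound 1 stands at > 10000 nM in the same test.

The next structure, `COc1ccc(CN2CCC=C(CCC(=O)NO)C2=O)cc1`, is compound 3, which has not yet been measured. The change is methoxy in place of acetamido on an aromatic carbon, with methoxy in place of acetamido on an aromatic carbon, para to a large group.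

Among the compounds with values here, no measured step shows what such a swap does. Within the data shown here, the sole guide is compound 1, which also carries a methoxy on its aromatic ring and reads > 10000 nM as a limit. Compound 3 is therefore expected to lie close to that limit, with no step beyond the usual scatter. For compound 3 the estimated value is 12000 nM, with an expected range from 3000 nM to 50000 nM, and a reported limit rather than a number would be no surprise.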

Compound 3, concentration for 50% growth inhibition: 1670 nM
For compound 3 the middle estimate is 7.2-fold (0.86 log units) above the measured one; measured number below the stated range.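

No step can be read from compound 3: compound 2 carries no number to compare with it, and compound 1 offers only a limit. As far as these compounds go, what replacing acetamido with methoxy does to the result in this assay therefore stays open.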